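The source may report more compounds than this note shows. Statements on the series, on what has been measured and on what is new or still open speak of the compounds shown alone.

Compound 1, `COc1ccc(/C=N/NC(=O)Nc2ccc(Oc3ccnc4cc(OCCCN5CCCCC5)c(OC)cc34)c(F)c2)cc1`: 590 nM
Compound 2, `COc1cc2c(Oc3ccc(NC(=O)N/N=C/c4ccc(Cl)cc4Cl)cc3F)ccnc2cc1OCCCN1CCCCC1`: 370 nM
Compound 3, `COc1cc2c(Oc3ccc(NC(=O)N/N=C/c4cccs4)cc3F)ccnc2cc1OCCCN1CCCCC1`: 770 nM

These three compounds share one core and differ only in the aryl group on the carbon with a double bond to nitrogen. All were tested in a functional assay on HT-29 cells (Homo sapiens) for cytotoxicity, read by MTT assay, with a stated time of 72 h; a lower number here means a stronger inhibitor, a higher number a weaker inhibitor. Compound 1 stands second highest of the three numbers. Its nearest neighbour is compound 3, as the step of a 1.3-fold higher number from compound 1 to compound 3 (0.12 log units; within the scatter) shows, and its furthest is compound 2, as the step of a 1.6-fold lower number from compound 1 to compound 2 (0.20 log units; within the scatter) shows. Within the data shown here, the only step reaching beyond the scatter is a 2.1-fold higher number from compound 2 to compound 3 (0.32 log units; beyond the scatter), and even that is modest.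

Compound 4, `COc1ccc(/C=N/NC(=O)Nc2ccc(Oc3ccnc4cc(OCCCN5CCC(C)CC5)c(OC)cc34)c(F)c2)cc1`, has not yet been measured. It differs from compound 1 by methyl in place of hydrogen on a saturated ring carbon. Among the measured compounds shown here, none of the measured steps touches this part of the molecule: each of them changes the aryl group at the other end and leaves the piperidin-1-yl as it is. With nothing measured that bears on this change, no step beyond the scatter is expected in this assay. For compound 4 the estimated value is 590 nM, with an expected range from 250 nM to 1400 nM. This estimate corresponds to an expected step of no change at the digits printed from compound 1 to compound 4 (within the scatter).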

Compound 4, half-maximal inhibitory concentration: 610 nM
For compound 4 the middle estimate is 1.0-fold (0.01 log units) below the measured one; low and high end bracket the measured number.
By their numbers in this assay, from the lowest: compounds 2, 1, 4 and 3 (each within the scatter of the next, the first and the last beyond it).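

In this assay, turning piperidin-1-yl into 4-methylpiperidin-1-yl, with the methyl on the saturated ring carbon three ring bonds from the ring nitrogen, gives a 1.0-fold higher number from compound 1 to compound 4 (0.01 log units; within the scatter) and leaves the two compounds indistinguishable. This is the only step shown at this end of the molecule, as all the earlier steps changed the aryl group, and it shows that this ring carbon can carry a methyl with no readable difference in this assay, at least alongside 4-methoxyphenyl. Nothing measured here offers an explanation for this result.

As far as these compounds go, whether a hydroxyl or a benzyl group at this ring carbon, or a morpholin-4-yl in place of the piperidine, would behave the same way remains open. So does the effect of this methyl alongside 2,4-dichlorophenyl or thiophen-2-yl at the other end.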